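The source may hold more compounds than are shown below. What is called first, only, known or untested is meant among the compounds shown, and "the series" means these compounds.

Measured in a functional assay on P388 cells (Mus musculus) for cytotoxicity; a lower number here means a stronger inhibitor, a higher number a weaker inhibitor:
Compound 1 `C[C@@H]1NC(=O)[C@@H](C)NC(=O)[C@@H]2Cc3cccc(c3)Oc3ccc(cc3)C[C@@H](C(=O)N2C)N(C)C(=O)[C@H](C)NC(=O)[C@H](Cc2ccccc2)N(C)C1=O`: 525 nM
Compound 2 `COc1ccc2cc1Oc1ccc(cc1)C[C@H]1C(=O)N(C)[C@@H](C2)C(=O)N[C@H](C)C(=O)N[C@@H](C)C(=O)N(C)[C@@H](Cc2ccccc2)C(=O)N[C@@H](C)C(=O)N1C`: 295 nM

Of these two compounds, compound 2 at 295 nM stands within the scatter of compound 1, so neither stands apart. Compound 3 `CCCc1ccc(C[C@H]2C(=O)N[C@@H](C)C(=O)N(C)[C@H]3Cc4ccc(cc4)Oc4cc(ccc4OC)C[C@@H](C(=O)N[C@H](C)C(=O)N[C@@H](C)C(=O)N2C)N(C)C3=O)cc1` carries propyl in place of hydrogen on an aromatic carbon of compound 2: propyl in place of hydrogen on an aromatic carbon. Within the data shown here, the only measured step, a 1.8-fold lower number from compound 1 to compound 2 (0.25 log units; within the scatter), places methoxy on an aromatic carbon and stays within the scatter. Among the measured compounds shown here, no measured step involves propyl, so this one bears only loosely. No shift beyond the scatter is therefore expected in this assay. The expected change is a 1.4-fold higher number from compound 2 to compound 3 (0.13 log units; within the scatter). For compound 3 the estimated value is 400 nM, with an expected range of 120 nM to 1300 nM.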

Compound 3, half-maximal inhibitory concentration: 25.7 nM
The estimate for compound 3 lay 16-fold (1.19 log units) above the measured number; the measured number lies below the stated range.
By their numbers in this assay, from the lowest: compound 3; then compounds 2 and 1 (each within the scatter of the next).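

In this assay the change from benzyl to 4-propylbenzyl brings an 11-fold lower number from compound 2 to compound 3 (1.06 log units; beyond the scatter) and lies beyond the scatter, which the earlier methoxy step did not. It shows that this position on the carbon-only aromatic ring, para to a large group, is sensitive to substitution: propyl, with no hydrogen-bond donors or acceptors, makes a large difference here. Nothing at hand explains this step.
The compounds shown leave open whether a methyl group or a longer chain such as butyl would give a similar number, and how an amine or a carboxylic acid at this place would behave.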